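The compounds below may be only part of what the source reports. "The series", "measured", "known", "first", "only" and "open" are said of these compounds alone.

Series notes. Of the compounds shown here, three of the shared core have been measured in a functional assay on the whole organism (strain albino) for inhibition, with Rattus norvegicus as the target, read by paw edema, with stated times of 1 h and 3 h, at a dose of 25 mg/kg by the oral route; a higher number here means more inhibition at the dose given (going by the name of the read-out), a lower number less inhibition. Compound 1 `CC1=C(C(=O)Nc2ccc(F)cc2)C(c2ccc(Br)cc2)n2c(s/c(=C/c3ccc(Cl)cc3)c2=O)=N1` gives 25%; compound 2 `CC1=C(C(=O)Nc2ccc(F)cc2)C(c2ccc([N+](=O)[O-])cc2)n2c(s/c(=C/c3ccc(Cl)cc3)c2=O)=N1` gives 23%; compound 3 `CC1=C(C(=O)Nc2ccc(F)cc2)C(c2ccc(F)cc2)n2c(s/c(=C/c3ccc([N+](=O)[O-])cc3)c2=O)=N1` gives 30%. Compound 3 holds the highest of the three numbers, yet its gaps to compound 1 and to compound 2 both lie within the scatter, so no ordering among the three is claimed. One measured step links two neighbours: a number 2 percentage points lower from compound 1 to compound 2 (within the scatter).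

Compound 4 `CC1=C(C(=O)Nc2ccc(F)cc2)C(c2ccc(F)cc2)n2c(s/c(=C/c3ccc(Cl)cc3)c2=O)=N1` is not yet measured. It differs from compound 3 by chloro in place of nitro on an aromatic carbon. Among the compounds with values here, the step from compound 1 to compound 2 is the nearest precedent, a nitro-for-halogen exchange on the other six-membered ring, and it stayed within the scatter. The present exchange sits on a different ring and runs the other way, so the precedent is indirect, but nothing in the measured numbers points to a step beyond the scatter in this assay. The expected step is a number 3 percentage points lower from compound 3 to compound 4 (within the scatter), which is no change beyond the scatter. Compound 4 is estimated to give 27%, with a range from 17% to 37%.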

Compound 4, a percentage reported as inhibition, in the whole organism at one dose (the size of the read-out at that dose, not a potency): 47%
Compound 4: the middle estimate sits 20 percentage points below what was measured; the measured number lies above the stated range.
By their numbers in this assay, from the lowest: compounds 2, 1 and 3 (each within the scatter of the next); then compound 4.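

Within the data shown here, at this position, para to a large group, chloro in place of nitro gives the first step in this assay beyond the scatter (a number 17 percentage points higher from compound 3 to compound 4 (beyond the scatter)). The ring carrying the other substituent is also sensitive: fluoro in place of nitro (a number 24 percentage points higher from compound 2 to compound 4 (beyond the scatter)) and fluoro in place of bromo (a number 22 percentage points higher from compound 1 to compound 4 (beyond the scatter)) both pass the scatter, whereas nitro in place of bromo did not (a number 2 percentage points lower from compound 1 to compound 2 (within the scatter)). Among these compounds, only the combination of fluoro and chloro in compound 4 stands apart, since compound 3 carries the fluoro and compound 1 and compound 2 carry the chloro without matching it.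

No measurement at hand explains these steps. As far as these compounds go, whether an amine, a methoxy group or a carboxylic acid in place of chloro at this position would hold, raise or lower the number remains open.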